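From 3-methylbenzyl to 3,4-dichlorobenzyl

The source may hold more compounds than are shown below. What is called first, only, known or untested is meant among the compounds shown, and "the series" means these compounds.

In a functional assay on CCRF-CEM cells (Homo sapiens) for antiproliferative activity, with a stated time of 72 h (on this read-out higher numbers stand for weaker inhibition and lower numbers for stronger inhibition), compound 1 `OC[C@H]1O[C@@H](n2cnc3c(NCc4cccc(Br)c4)ncnc32)[C@H](O)[C@@H]1O` gives 5000 nM and compound 2 `Cc1cccc(CNc2ncnc3c2ncn3[C@@H]2O[C@H](CO)[C@@H](O)[C@H]2O)c1` gives 19100 nM. Compound 2 thus holds the higher of the two numbers, the weaker inhibition so far. Going by the values given here, the one measured step, a 3.8-fold higher number from compound 1 to compound 2 (0.58 log units; beyond the scatter), is methyl in place of bromo on an aromatic carbon, modest but beyond the scatter.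

Compound 3 `OC[C@H]1O[C@@H](n2cnc3c(NCc4ccc(Cl)c(Cl)c4)ncnc32)[C@H](O)[C@@H]1O` has 3,4-dichlorophenyl in place of 3-methylphenyl on a saturated chain carbon bound to a nitrogen on an aromatic ring. This removes the methyl and returns halogen to the ring. With bromo-bearing compound 1 at 5000 nM, a modest move to a lower number is expected in this assay. Among the compounds with values here, no measured compound carries chlorine, so the range stays wide. The expected step is a 3.5-fold lower number from compound 2 to compound 3 (0.54 log units; beyond the scatter). For compound 3 the estimate is 5500 nM, with an expected range of 1800 nM to 16000 nM.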

Compound 3, half-maximal inhibitory concentration: 3800 nM
Compound 3: middle estimate off by 1.4-fold (0.16 log units), on the high side; low and high end bracket the measured number.
By their numbers in this assay, from the lowest: compounds 3 and 1 (each within the scatter of the next); then compound 2.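

Working from the 3-methylphenyl group, 3,4-dichlorophenyl on the same saturated chain carbon gives a clear change in this assay (a 5.0-fold lower number from compound 2 to compound 3 (0.70 log units; beyond the scatter)). Against 3-bromophenyl, the same group gives no separable change (a 1.3-fold lower number from compound 1 to compound 3 (0.12 log units; within the scatter)). Among these three compounds, both halogen-bearing benzyl groups therefore stand apart from the 3-methylbenzyl group of compound 2, and no compound shown goes against this, although the bromo to dichloro step changes the halogen and the substitution together. No measurement at hand accounts for these steps.

It remains open whether one chlorine would serve as well as two, as the 3-chlorophenyl and 4-chlorophenyl groups do not appear among the compounds shown. Also open, from the compounds shown here alone, is how this position responds to a group other than halogen or methyl, such as methoxy, an amine or a carboxylic acid on the phenyl ring.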